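The compounds below may be only part of what the source reports. "The series", "measured", "known", "first", "only" and "open" are said of these compounds alone.

Compound 1 `O=C(NCc1ccccc1)c1cn(-c2ccccc2)nc1-c1ccsc1`, compound 2 `COc1ccc(OC(=O)c2cn(-c3ccccc3)nc2-c2ccsc2)cc1` and compound 3 `CCc1ccc(OC(=O)c2cn(-c3ccccc3)nc2-c2ccsc2)cc1` share one core and differ only at the carbonyl carbon or on the aryl ester. In a functional assay on HL-60 cells (Homo sapiens) for inhibition, read by MTT assay, with a stated time of 48 h (a lower number here means a stronger inhibitor, a higher number a weaker inhibitor), compound 1 gives > 100000 nM, which is a limit of the assay and not a number. In this assay compound 2 gives > 100000 nM, also a limit. In this assay compound 3 gives > 100000 nM, again a limit. The steps a step that the two limits leave unreadable from compound 1 to compound 2, a step that the two limits leave unreadable from compound 1 to compound 3 and a step that the two limits leave unreadable from compound 2 to compound 3 therefore have no readable size, all three values sitting at the limit of > 100000 nM in this assay, at which 3 of the 3 values shown sit. Compound 4 `O=C(Oc1ccc(-c2ccccc2)cc1)c1cn(-c2ccccc2)nc1-c1ccsc1` differs from compound 3 by phenyl in place of ethyl on an aromatic carbon. Within the data shown here, no measured step gives a number, so neither size nor direction can be read for the step of a number no higher from compound 3 to compound 4 (the limit leaves the size open) that is expected. Compound 4 is expected to give 100000 nM, within 30000 nM to 300000 nM, most probably again only a limit.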

Compound 4, half-maximal inhibitory concentration: > 100000 nM
Compound 4: no number, only a limit (the forecaster's own chance of this, stated with the estimate: 80%); the middle value sits exactly at the limit.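

In this assay compound 4 gives > 100000 nM, a limit and not a number, and the steps to it from compound 2 and compound 3 cannot be read. The compounds shown leave open whether any change on the shared core gives a measurable value, as all sit at one limit: the limit of > 100000 nM in this assay, at which 4 of the 4 values shown sit.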